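The source may report more compounds than this note shows. Statements on the series, on what has been measured and on what is new or still open speak of the compounds shown alone.

Compounds measured so far:
- Compound 1 `O=c1nc(-c2ccccc2)c2cc(-c3cccnc3)ccc2[nH]1`: in an ADME assay on THP-1 cells (Homo sapiens) for cytotoxicity, read by MTT assay, with a stated time of 72 h (a higher number here means that more compound is needed for the effect, a lower number that less compound is needed), compound 1 gives > 50000 nM.
- Compound 2 `Cc1cncc(-c2ccc3[nH]c(=O)nc(-c4ccccc4)c3c2)c1`: compound 2 gives > 50000 nM.
- Compound 3 `Cn1ccc(-c2cccc3[nH]c(=O)nc(-c4ccccc4)c23)n1`: compound 3 gives > 50000 nM.

Each of these three values is a limit of the assay and not a number, so compound 1 stands only at the limit of > 50000 nM in this assay, at which 3 of the 3 values shown sit. Compound 4 `Cc1ccc2[nH]c(=O)nc(-c3ccccc3)c2c1` differs from compound 1 by methyl in place of pyridin-3-yl on an aromatic carbon. For the measured compounds named here, the single measured step bearing on this change, a step that the two limits leave unreadable from compound 1 to compound 2, cannot be read because both of its ends sit at the limit, so its size is unknown. No readable step is therefore expected for compound 4; the step that the limit leaves unreadable from compound 1 to compound 4 is an estimate only. Compound 4 is expected to give about 80000 nM, with a range from 40000 nM to 200000 nM.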

Compound 4, half-maximal effective concentration: > 50000 nM
Compound 4 gave a limit, no number; the forecaster's own chance of this, stated with the estimate: 85%; the middle value does not contradict the limit.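

For the compounds shown here, no step from compound 1 or compound 2 to compound 4 can be read, since each compound gives a limit and not a number: the limit of > 50000 nM in this assay, at which 4 of the 4 values shown sit. The compounds shown leave open whether they differ at all, and whether any change on the shared core would give a readable value.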